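The compounds below may be only part of what the source reports. "The series", "measured", "known", "first", "only" and "open" are said of these compounds alone.

Compound 1 `Cc1cc(Nc2cc(-c3ccccc3)[nH]n2)n2nc(SCc3ccc(F)cc3)nc2n1` gives 3270 nM
Compound 2 `Cc1cc(Nc2cc(-c3ccccc3)[nH]n2)n2nc(SCc3cccc(Br)c3)nc2n1` gives 4820 nM
Compound 3 `Cc1cc(Nc2cc(-c3ccccc3)[nH]n2)n2nc(SCCCc3ccccc3)nc2n1` gives 6510 nM

All three values come from a functional assay on MGC-803 cells (Homo sapiens) for inhibition, read by MTT assay, with a stated time of 72 h; a higher number here means a weaker inhibitor, a lower number a stronger inhibitor. Compound 3 stands level with the other two, since a 2.0-fold higher number from compound 1 to compound 3 (0.30 log units; within the scatter) and a 1.4-fold higher number from compound 2 to compound 3 (0.13 log units; within the scatter) both stay within the scatter. Compound 4 `C=CCSc1nc2nc(C)cc(Nc3cc(-c4ccccc4)[nH]n3)n2n1` carries vinyl in place of phenethyl on a saturated chain carbon bound to a sulfur. Within the data shown here, this change drops an aromatic ring, and no measured step does that, so the guidance is indirect. The closest guides, a 1.5-fold higher number from compound 1 to compound 2 (0.17 log units; within the scatter) and the two above, suggest no expected step beyond the scatter in this assay, in either direction. The expected change is a 1.1-fold lower number from compound 3 to compound 4 (0.04 log units; within the scatter). Compound 4 is estimated at 6000 nM, with an expected range of 2500 nM to 15000 nM.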

Compound 4, half-maximal inhibitory concentration: 17200 nM
For compound 4 the middle estimate is 2.9-fold (0.46 log units) below the measured one; the whole stated range lies below it.
By their numbers in this assay, from the lowest: compounds 1, 2 and 3 (each within the scatter of the next); then compound 4.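

Among these compounds, replacing a ring-bearing group with vinyl, on a saturated chain carbon bound to a sulfur, gives the first steps here that clear the scatter in this assay: a 2.6-fold higher number from compound 3 to compound 4 (0.42 log units; beyond the scatter) and a 3.6-fold higher number from compound 2 to compound 4 (0.55 log units; beyond the scatter) and a 5.3-fold higher number from compound 1 to compound 4 (0.72 log units; beyond the scatter) in turn. Among the compounds shown here, compounds 1, 2 and 3 all keep an aromatic ring and stay within the scatter of one another, while compound 4, the only one without that ring, has the highest number. Nothing available explains this loss. Compound 4 loses the ring and shrinks the group in one change, so the two effects cannot be separated. A cyclohexylmethyl group or a plain hexyl chain at this position would help tell them apart.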